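Replacing a Cyclic Cyanoguanidine with a Small Amide

This account rests on a few compounds, and the source may have more. Where it says the series, first, only, none or still open, it means among the compounds named here.

Compound 1 `CC(C)C(c1ncc[nH]1)c1ccc(-c2ccc3cccc(F)c3c2)[nH]c1=O`: 7.3 nM
Compound 2 `CC(C)C(c1ccc(-c2ccc3cccc(F)c3c2)[nH]c1=O)N1CCCCC1=O`: 6.4 nM
Compound 3 `CC(C)C(c1ccc(-c2ccc3cccc(F)c3c2)[nH]c1=O)N1CCN/C1=N\C#N`: 23 nM

In an assay on CHO cells for displacement of a labelled ligand from prostaglandin E2 receptor EP3 subtype (Homo sapiens), read by radioligand binding (on this read-out lower numbers stand for stronger inhibition and higher numbers for weaker inhibition), compound 3 stands highest of the three, with compound 1 and compound 2 both sitting below it by more than the scatter. Compound 4 `CC(C)C(CC(N)=O)c1ccc(-c2ccc3cccc(F)c3c2)[nH]c1=O` differs from compound 3 by a group of 4 heavy atoms (2 carbon, 1 nitrogen, 1 oxygen; no ring) in place of a group of 8 heavy atoms (4 carbon, 4 nitrogen; one five-membered non-aromatic ring with 2 hetero atoms), on a saturated chain carbon bound to an aromatic carbon and a saturated chain carbon. For the measured compounds named here, two measured steps bear on this change, since both exchange the same eight-atom ring group for something else at the same place: a 3.2-fold higher number from compound 1 to compound 3 (0.50 log units; beyond the scatter) and a 3.6-fold higher number from compound 2 to compound 3 (0.56 log units; beyond the scatter). Read backwards, both point the same way, so a modest drop in the number is expected when this ring group leaves again. Compound 4 is therefore estimated at 10 nM, within a range from 4 nM to 30 nM. This estimate means an expected step of a 2.3-fold lower number from compound 3 to compound 4 (0.36 log units; beyond the scatter).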

Compound 4, inhibition constant: 5 nM
For compound 4 the middle estimate is 2.0-fold (0.30 log units) above the measured one; measured number inside the range.
By their numbers in this assay, from the lowest: compounds 4, 2 and 1 (each within the scatter of the next); then compound 3.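

In this assay the carbamoylmethyl group, which has no ring, holds its own at this place on the saturated chain carbon: a 1.3-fold lower number from compound 2 to compound 4 (0.11 log units; within the scatter) and a 1.5-fold lower number from compound 1 to compound 4 (0.16 log units; within the scatter) both stay within the scatter, whereas a 4.6-fold lower number from compound 3 to compound 4 (0.66 log units; beyond the scatter) lies beyond it. A ring on this carbon is therefore not needed among these compounds, and only the ring group of compound 3 stands apart from the other three. Nothing shown gives a reason for this. From the compounds shown here alone, whether a carboxylic acid, an amine or a longer chain would fit here as well remains open.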